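Methoxy for fluoro on the aryl ring, cytotoxicity series

The source may hold more compounds than are shown below. What is called first, only, known or untested is meant among the compounds shown, and "the series" means these compounds.

Working notes on compound 1 `C=CC1=C(C(=O)NC(C)(C)C)C(c2ccc(OC)cc2)OC1`, compound 2 `C=CC1=C(C(=O)NCCCCC)C(c2ccc(F)cc2)OC1` and compound 3 `C=CC1=C(C(=O)NCCCCC)C(c2ccc(OC)cc2)OC1`, read in a functional assay on HeLa cells (Homo sapiens) for cytotoxicity, read by MTT assay, with a stated time of 24 h; a lower number here means a stronger inhibitor, a higher number a weaker inhibitor. Compound 1 sits at a limit of the assay and gives > 100000 nM. Compound 2 likewise sits at a limit and gives > 100000 nM. Compound 3 differs from compound 2 by methoxy in place of fluoro on an aromatic carbon. For the measured compounds named here, no step between measured compounds is known, and no shift beyond the scatter is expected, because compound 1 and compound 2 both rest at the same limit (the limit of > 100000 nM in this assay, at which 2 of the 2 values shown sit). Compound 3 is estimated at 100000 nM, within 40000 nM to 300000 nM. The expected step is then a number no higher from compound 2 to compound 3 (the limit leaves the size open).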

Compound 3, half-maximal inhibitory concentration: > 100000 nM
Compound 3: no number, only a limit (the forecaster's own chance of this, stated with the estimate: 85%); the middle value sits exactly at the limit.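

For the compounds shown here, compound 3 gives > 100000 nM in this assay and this is a limit of the assay, so no step linking it to compound 1 or compound 2 can be read: the limit of > 100000 nM in this assay, at which 3 of the 3 values shown sit. Going by these compounds, whether methoxy in place of fluoro, or pentyl in place of tert-butyl, shifts cytotoxicity at all stays open.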